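Piperidinyl Sulfonamide in Place of a Hydroxyethyl Sulfonamide

The source may hold more compounds than are shown below. What is called first, only, known or untested is meant among the compounds shown, and "the series" means these compounds.

Of the compounds shown here, three on a shared core have been tested in a physicochemical assay for solubility, read by HPLC, using the shake flask method, measured as kinetic solubility, with a stated time of 20 h, at pH 6.5, tested at 200 uM; on this read-out lower numbers stand for lower solubility and higher numbers for higher solubility. Compound 2 `O=S(=O)(NCCO)c1cccc(Nc2ccc3nccc(-c4ccncc4)c3n2)c1` gives 115000 nM, the highest of the two numbers recorded. Compound 1 `O=S(=O)(c1cccc(-c2ccc3nccc(-c4ccncc4)c3n2)c1)N1CCC(O)CC1` gives 10000 nM, a gap beyond the usual scatter of this measurement. Compound 3 `NS(=O)(=O)c1cccc(-c2ccc3nccc(-c4cn[nH]c4)c3n2)c1` gives a limit of the assay rather than a number, < 5000 nM. That reading is the limit of < 5000 nM in this assay, at which 1 of the 3 values shown sits.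

Compound 4 `O=S(=O)(c1cccc(Nc2ccc3nccc(-c4ccncc4)c3n2)c1)N1CCCCC1` differs from compound 2 in a single place: piperidin-1-yl in place of (2-hydroxyethyl)amino on a sulfonyl sulfur. For the measured compounds named here, no measured pair covers exactly this exchange, so any expectation has to lean on the values already in hand. Compound 1, which also carries a piperidin-1-yl on its sulfonyl sulfur, gives 10000 nM, and on that footing compound 4 is expected to fall well short of compound 2. The expected step is a 14-fold lower number from compound 2 to compound 4 (1.16 log units; beyond the scatter), a loss of solubility. Compound 4 is estimated at 8000 nM, within a range from 2000 nM to 40000 nM, with a real chance that only a limit is reported.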

Compound 4, solubility: 15000 nM
Beside the measured number, compound 4's estimate is 1.9-fold (0.27 log units) below it; low and high end bracket the measured number.
By their numbers in this assay, from the lowest: compounds 1 and 4 (each within the scatter of the next); then compound 2. At a limit, below all of these: compound 3.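

For the compounds shown here, with the step to compound 4, the change of (2-hydroxyethyl)amino to piperidin-1-yl on a sulfonyl sulfur can be read directly for the first time: in this assay the exchange gives a 7.7-fold lower number from compound 2 to compound 4 (0.88 log units; beyond the scatter) on an otherwise unchanged structure. Going by these compounds alone, the earlier compounds differed in more than one place, so only this pair shows that the group on the sulfonyl sulfur alone can move the number by more than the usual scatter. No evidence at hand bears on why the number moves.

The exchange removes the open chain and its hydrogen-bond donors and brings in a ring all at once, and these cannot be separated on this pair. As far as these compounds go, whether a morpholine, a piperazine or a plain ethylamino on the same sulfonyl sulfur would stand nearer compound 2 or nearer compound 4 remains open.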